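Halogen Swap at the Aryl Ring: Expectation for Compound 3

The source may report more compounds than this note shows. Statements on the series, on what has been measured and on what is new or still open speak of the compounds shown alone.

Compound 1 `Sc1nnc(COc2ccc(-c3ccccc3)cc2)n1-c1ccc(Cl)cc1`: 18.2%
Compound 2 `Sc1nnc(COc2ccc(-c3ccccc3)cc2)n1-c1ccc(Br)cc1`: 31.8%

In a functional assay on the whole organism (strain Wistar) for inhibition, with Rattus norvegicus as the target, read by paw edema, with a stated time of 4 h, at a dose of 10 mg/kg by the oral route (a lower number here means less inhibition, a higher number more inhibition at the dose given (going by the name of the read-out)), compound 2 gives 31.8%, the highest of the two numbers, and compound 1 gives 18.2%. Going by the values given here, the only measured step, a number 13.6 percentage points higher from compound 1 to compound 2 (beyond the scatter), bears on the next change, since it also exchanges one halogen for another at the same aromatic carbon. Compound 3 `Fc1ccc(-n2c(S)nnc2COc2ccc(-c3ccccc3)cc2)cc1` differs from compound 2 by fluoro in place of bromo on an aromatic carbon. Among the compounds with values here, because the single halogen exchange a number 13.6 percentage points higher from compound 1 to compound 2 (beyond the scatter) moved the number modestly, another halogen exchange at this carbon is expected to move it modestly as well, here downward, by a number 13.8 percentage points lower from compound 2 to compound 3 (beyond the scatter). Compound 3 is therefore estimated at 18%, within a range of 5% to 32%.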

Compound 3, a percentage reported as inhibition, in the whole organism at one dose (the size of the read-out at that dose, not a potency): 79.5%
Compound 3: the middle estimate sits 61.5 percentage points below what was measured, and the stated range ends below it.
By their numbers in this assay, from the lowest: compound 1; then compound 2; then compound 3.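

In this assay the choice of halogen at this carbon proves to matter far more than the first exchange showed: fluoro in place of bromo gives a number 47.7 percentage points higher from compound 2 to compound 3 (beyond the scatter), and fluoro in place of chloro gives a number 61.3 percentage points higher from compound 1 to compound 3 (beyond the scatter). The numbers do not run in halogen order, since the bromo compound lies between the chloro and fluoro compounds. Nothing available explains this rise. Open, going by these compounds, is whether the gain is specific to fluoro or extends to a methoxy or trifluoromethyl group at this carbon, or to plain hydrogen. Also open, on these data alone, is whether the order of the three compounds holds at other doses.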